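Two pyrazolyl enones and a halogen swap on the aryl ketone

This account rests on a few compounds, and the source may have more. Where it says the series, first, only, none or still open, it means among the compounds named here.

Of the compounds shown here, two have been measured in a functional assay on SNB-19 cells (Homo sapiens) for cytotoxicity, read by sulforhodamine B assay, with a stated time of 48 h, tested at 1 uM; a higher number here means a weaker effect of the compound at the concentration tested, a lower number a stronger effect. Compound 1 `COc1ccc(-c2cc(/C=C/C(=O)c3ccc(N)cc3)[nH]n2)cc1` gives 75%. Compound 2 `COc1cc(-c2cc(/C=C/C(=O)c3ccc(Cl)c(Cl)c3)[nH]n2)cc(OC)c1OC` gives 90%, which is the higher of the two numbers and therefore the weaker effect, and its distance from the number of compound 1 lies beyond the usual scatter of this measurement. No single-change step between the two measured compounds exists, since they differ in more than one place, so nothing is said here about the cause of that gap.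

Compound 3 `COc1cc(-c2cc(/C=C/C(=O)c3ccc(F)c(F)c3)[nH]n2)cc(OC)c1OC` has not yet been measured. It differs from compound 2 in one place: 3,4-difluorophenyl in place of 3,4-dichlorophenyl on a carbonyl carbon. Both groups are of the same size and carry no donors or acceptors, and the two measured compounds give no guidance on how exchanging one halogen for another at this position moves the read-out in this assay. The expectation is therefore a step of a number 1 percentage points higher from compound 2 to compound 3 (within the scatter) that does not go beyond the scatter in either direction. On that basis compound 3 is expected to give about 91% in this assay, with a likely range from 78% to 104%.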

Compound 3, a percentage reported as activity, at one concentration (the size of the read-out at that concentration, not a potency): 82%
For compound 3 the middle estimate is 9 percentage points above the measured one; measured number inside the range.
By their numbers in this assay, from the lowest: compounds 1, 3 and 2 (each within the scatter of the next, the first and the last beyond it).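

Within the data shown here, this is the first single-change step among the compounds. In this assay the exchange of 3,4-dichlorophenyl for 3,4-difluorophenyl on a carbonyl carbon gives a number 8 percentage points lower from compound 2 to compound 3 (within the scatter) and so shows that, with the rest of the molecule held fixed, this swap of one halogen pair for another does not move the read-out beyond what repeated measurements can separate, something that the earlier pair, which differ in more than one place, could not show. No measured property of these compounds bears on this result, so the data offer no explanation for it.

The compounds shown leave open whether a different group on the same carbonyl carbon, such as 3,4-dibromophenyl, unsubstituted phenyl or a phenyl ring bearing a carboxylic acid, would shift the read-out beyond the scatter or stay level with this halogen pair. Also open, as far as these compounds go, is what a change elsewhere on the shared core would do, for instance a hydroxyl group in place of a methoxy group.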